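A Chlorine Swap on the Benzyl Ether Substituent

This account rests on a few compounds, and the source may have more. Where it says the series, first, only, none or still open, it means among the compounds named here.

Compound 3 (`COc1ccccc1COc1c(-c2ccccc2)oc2cc(O)cc(O)c2c1=O`) gives 53000 nM in an ADME assay on Huh-5-2 cells (Homo sapiens) for cytotoxicity, read by WST assay, with a stated time of 3 days (on this read-out higher numbers stand for lower toxicity in this test and lower numbers for higher toxicity in this test), the higher of the two plain numbers recorded, although its nearest neighbour sits within the scatter. That neighbour, compound 2 (`O=c1c(OCc2ccccc2[N+](=O)[O-])c(-c2ccccc2)oc2cc(O)cc(O)c12`), gives 51000 nM in this assay, and the step of a 1.0-fold higher number from compound 2 to compound 3 (0.02 log units; within the scatter) is within the scatter. Compound 1 (`N#Cc1ccccc1COc1c(-c2ccccc2)oc2cc(O)cc(O)c2c1=O`) reached only a limit of the test, > 100000 nM. Because the limit of > 100000 nM in this assay, at which 1 of the 3 values shown sits, bounds compound 1, the steps of an at least 1.9-fold lower number from compound 1 to compound 2 (0.29 log units; that floor lies within the scatter) and an at least 1.8-fold lower number from compound 1 to compound 3 (0.27 log units; that floor lies within the scatter) are known only as floors.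

Compound 4 (`O=c1c(OCc2cccc(Cl)c2)c(-c2ccccc2)oc2cc(O)cc(O)c12`) has not yet been measured in this assay. It differs from compound 3 by 3-chlorophenyl in place of 2-methoxyphenyl on a saturated chain carbon bound to an oxygen on an aromatic ring. For the measured compounds named here, no measured step involves a chlorine or a substituent in the 3-position of that ring, so the expectation rests on the step from compound 2 to compound 3, where exchanging one substituent on the same ring for another left the number within the scatter. The step of a 1.1-fold lower number from compound 3 to compound 4 (0.03 log units; within the scatter) is therefore expected to stay within the scatter. Compound 4 is estimated at 50000 nM, between 25000 nM and 100000 nM.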

Compound 4, half-maximal cytotoxic concentration: 46000 nM
Compound 4: middle estimate off by 1.1-fold (0.04 log units), on the high side; low and high end bracket the measured number.
By their numbers in this assay, from the lowest: compounds 4, 2 and 3 (each within the scatter of the next). At a limit, above all of these: compound 1.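

In this assay, 3-chlorophenyl on this saturated chain carbon gives a number that cannot be told apart from those of the 2-methoxyphenyl and 2-nitrophenyl groups: a 1.2-fold lower number from compound 3 to compound 4 (0.06 log units; within the scatter) and a 1.1-fold lower number from compound 2 to compound 4 (0.04 log units; within the scatter) both stay small, so compounds 2, 3 and 4 form one level despite the different substituents. For the compounds shown here, the step to compound 1 is the first at this place to clear the scatter, as an at least 2.1-fold lower number from compound 1 to compound 4 (0.33 log units; beyond the scatter) shows, whereas the floors to compound 2 and compound 3 do not. Compound 1 stands at a limit, > 100000 nM, so this step is known only as a floor: the limit of > 100000 nM in this assay, at which 1 of the 4 values shown sits.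

Going by these compounds, whether the level holds for an amine or a carboxylic acid on this ring remains open. So does the effect of a longer chain between the ring and the oxygen of the shared core.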